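The source may report more compounds than this note shows. Statements on the series, on what has been measured and on what is new or still open speak of the compounds shown alone.

Working notes on the series.

Compound 1 `CCN(CC)CCn1c(N)c(-c2nc3ccccc3[nH]2)c2nc(C#N)c(C#N)nc21` carries a basic chain on the ring nitrogen of the shared core; in a functional assay on HL-60 cells (Homo sapiens) for antiproliferative activity, read by MTT assay, with a stated time of 48 h (on this read-out lower numbers stand for stronger inhibition and higher numbers for weaker inhibition), compound 1 gives 1880 nM. Compound 2 `CN(C)CCCn1c(N)c(-c2nc3ccccc3[nH]2)c2nc(C#N)c(C#N)nc21` differs from compound 1 by (dimethylamino)methyl in place of diethylamino on a saturated chain carbon, two bonds along the chain from an aromatic nitrogen and in this assay compound 2 gives 870 nM, a change of a 2.2-fold lower number from compound 1 to compound 2 (0.33 log units; beyond the scatter). Compound 3 `CCN(CC)CCn1c(N)c(-c2nc3ccccc3n2C)c2nc(C#N)c(C#N)nc21` differs from compound 1 by methyl in place of hydrogen on an aromatic nitrogen; in this assay compound 3 gives 8800 nM, a change of a 4.7-fold higher number from compound 1 to compound 3 (0.67 log units; beyond the scatter), and it shows the highest number of the three measured compounds.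

Compound 4 `CN(C)CCCn1c(N)c(-c2nc3ccccc3n2C)c2nc(C#N)c(C#N)nc21` is not yet measured. It stands to compound 3 as compound 2 stands to compound 1, the difference being ((dimethylamino)methyl in place of diethylamino on a saturated chain carbon, two bonds along the chain from an aromatic nitrogen). This change occurs twice among the compounds shown, once with a measured result. The place description is the same word for word in both pairs, so it is taken as the same change, applied to cores that differ by methyl in place of hydrogen on an aromatic nitrogen. Going by these compounds, whether the step transfers onto the methylated core is untested; no second measured instance exists.

In this assay the step from compound 3 to compound 4 is expected to be about a 2.2-fold lower number from compound 3 to compound 4 (0.34 log units; beyond the scatter), beside the measured step of a 2.2-fold lower number from compound 1 to compound 2 (0.33 log units; beyond the scatter), resting solely on that one pairing in compound 1 and compound 2. For compound 4 the expected value in this assay is 4000 nM. Going by the values given here, the range for compound 4 is estimated as 1500 nM to 10000 nM, widened because the single measured step of a 2.2-fold lower number from compound 1 to compound 2 (0.33 log units; beyond the scatter) is modest and the core here is different.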

Compound 4, half-maximal inhibitory concentration: 2120 nM
Beside the measured number, compound 4's estimate is 1.9-fold (0.28 log units) above it; the measured number falls inside the stated range.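

In this assay the change from diethylamino to (dimethylamino)methyl on the saturated chain carbon carries over to the methylated core, with a 4.2-fold lower number from compound 3 to compound 4 (0.62 log units; beyond the scatter), and it runs the same way and agrees with the step on the core of compound 1: the same change on two cores in this assay, a 2.2-fold lower number (0.33 log units; beyond the scatter) from compound 1 to compound 2 and a 4.2-fold lower number (0.62 log units; beyond the scatter) from compound 3 to compound 4, 1.9-fold (0.28 log units) apart, within the scatter of two such steps.

Read the other way round, methyl in place of hydrogen on an aromatic nitrogen also gives a higher number on the 3-(dimethylamino)propyl chain, with a 2.4-fold higher number from compound 2 to compound 4 (0.39 log units; beyond the scatter), and this agrees with the step on the 2-(diethylamino)ethyl chain: the same change on two cores in this assay, a 4.7-fold higher number (0.67 log units; beyond the scatter) from compound 1 to compound 3 and a 2.4-fold higher number (0.39 log units; beyond the scatter) from compound 2 to compound 4, 1.9-fold (0.28 log units) apart, within the scatter of two such steps.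

These two comparisons come from the same four compounds, so they are one test of additivity rather than two, and they do not show that either step is larger on one core than on the other, nor that it would hold on any further core.

The chain change alters chain length and the groups on the amine together, so the compounds shown leave open how much each part contributes. A 3-(diethylamino)propyl or 2-(dimethylamino)ethyl chain would separate the two, while a cyclic amine such as morpholine at the chain end, or ethyl on the aromatic nitrogen, remains an open case for the same comparison.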